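Swapping the Amide Aryl Group: Compound 3 to Compound 4

The compounds below may be only part of what the source reports. "The series", "measured", "known", "first", "only" and "open" are said of these compounds alone.

Compound 1, `O=C(Nc1cccc(-c2oc3cc(-c4ccc(F)cc4)ccc3c(=O)c2O)c1)c1ccc(F)cc1F`, gives 20500 nM in a functional assay on A549 cells (Homo sapiens) for antiproliferative activity, read by CCK-8 assay, with a stated time of 72 h; on this read-out higher numbers stand for weaker inhibition and lower numbers for stronger inhibition.
Compound 2, `Cc1ccccc1C(=O)Nc1cccc(-c2oc3cc(-c4ccc(F)cc4)ccc3c(=O)c2O)c1`, gives 17600 nM.
Compound 3, `CCc1ccc(C(=O)Nc2cccc(-c3oc4cc(-c5ccc(F)cc5)ccc4c(=O)c3O)c2)cc1`, gives 18500 nM.

All three compounds share the same core and differ only in the aryl group attached to the amide carbonyl carbon. Compound 3 holds the second highest of the three numbers, yet its separation from either neighbour is small: a 1.1-fold higher number from compound 2 to compound 3 (0.02 log units; within the scatter) and a 1.1-fold lower number from compound 1 to compound 3 (0.04 log units; within the scatter) both fall within the scatter, as does a 1.2-fold lower number from compound 1 to compound 2 (0.07 log units; within the scatter). So far, changing this aryl group has not moved the read-out beyond what repeated measurements would show on their own.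

Compound 4, `COc1ccc(C(=O)Nc2cccc(-c3oc4cc(-c5ccc(F)cc5)ccc4c(=O)c3O)c2)c(F)c1`, continues this line: 2-fluoro-4-methoxyphenyl in place of 4-ethylphenyl on a carbonyl carbon. The three measured steps are the ones that bear on it, since each of them also exchanges the aryl group on the carbonyl carbon, and none of them produced a change beyond the scatter. On that basis, the expected step in this assay from compound 3 to compound 4 is none beyond the scatter, in either direction, which is what the estimate a 1.0-fold higher number from compound 3 to compound 4 (0.01 log units; within the scatter) means.

Compound 4 is therefore expected to give about 19000 nM, with a likely range from 10000 nM to 38000 nM.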

Compound 4, half-maximal inhibitory concentration: 40000 nM
Beside the measured number, compound 4's estimate is 2.1-fold (0.32 log units) below it; measured number above the stated range.
By their numbers in this assay, from the lowest: compounds 2, 3, 1 and 4 (each within the scatter of the next, the first and the last beyond it).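

In this assay, the aryl group on the carbonyl carbon now shifts the read-out beyond the scatter, which none of the exchanges among compounds 1, 2 and 3 did: 2-fluoro-4-methoxyphenyl gives a 2.2-fold higher number from compound 3 to compound 4 (0.33 log units; beyond the scatter) and a 2.3-fold higher number from compound 2 to compound 4 (0.36 log units; beyond the scatter) and both are modest steps towards weaker inhibition. The position is therefore not wholly indifferent to what sits there, but the picture is incomplete, as the step that exchanges only methoxy for fluoro on an aromatic carbon, a 2.0-fold higher number from compound 1 to compound 4 (0.29 log units; within the scatter) and so stays within the scatter, does not separate these two compounds, even though compound 1 itself sits within the scatter of compounds 2 and 3. No measurement at hand explains why the read-out moves with this group.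

From the compounds shown here alone, all four compounds carry a substituted phenyl group on this carbonyl carbon, so it remains open how a saturated amine such as piperidine, or a phenyl group bearing a carboxylic acid, would read here. Going by these compounds, it also remains open how plain 4-methoxyphenyl would read, which would help to separate the part played by the methoxy group from that of the fluoro group in compound 4.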